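The source may report more compounds than this note shows. Statements on the series, on what has been measured and on what is new or still open speak of the compounds shown alone.

Compound 1 `Cc1ccccc1-c1cc(N2CCN(C)CC2)ccc1C(=O)N(C)Cc1cc(C(F)(F)F)cc(C(F)(F)F)c1`, compound 2 `Cc1ccccc1-c1ccc(N2CCN(C)CC2)nc1C(=O)N(C)Cc1cc(C(F)(F)F)cc(C(F)(F)F)c1` and compound 3 `Cc1ccccc1-c1ccccc1C(=O)N(C)Cc1cc(C(F)(F)F)cc(C(F)(F)F)c1` share most of their framework, and compound 4 `Cc1ccccc1-c1cccnc1C(=O)N(C)Cc1cc(C(F)(F)F)cc(C(F)(F)F)c1` remains to be measured. In an assay on CHO cells for displacement of a labelled ligand from Substance-P receptor (Homo sapiens) (a lower number here means a stronger inhibitor, a higher number a weaker inhibitor), compound 1 gives 1.4 nM, compound 2 gives 6.2 nM and compound 3 gives 17 nM. The change from compound 1 to compound 3 is hydrogen in place of 4-methylpiperazin-1-yl on an aromatic carbon and produces a step of a 12-fold higher number from compound 1 to compound 3 (1.08 log units; beyond the scatter). The difference between the cores of compound 1 and compound 2 is not broken down here. Compound 4 arises from compound 2 through (hydrogen in place of 4-methylpiperazin-1-yl on an aromatic carbon), the same kind of change, though the place now lies on a six-membered aromatic ring with one nitrogen, next to the ring nitrogen, meta to a large group and para to a 2-methylphenyl group, whereas in compound 1 it lay on a ring of carbon only, meta to the 2-methylphenyl group and para to a large group. Resting on the earlier step of a 12-fold higher number from compound 1 to compound 3 (1.08 log units; beyond the scatter), a step of a 9.7-fold higher number from compound 2 to compound 4 (0.99 log units; beyond the scatter) is expected in this assay. Compound 4 is estimated at 60 nM, within a range from 20 nM to 180 nM.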

Compound 4, inhibition constant: 3.8 nM
Compound 4: the middle estimate sits 16-fold (1.20 log units) above what was measured; measured number below the stated range.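

In this assay, the replacement of 4-methylpiperazin-1-yl by hydrogen does not carry over from one core to the other: the same change on two cores in this assay, a 12-fold higher number (1.08 log units; beyond the scatter) from compound 1 to compound 3 and a 1.6-fold lower number (0.21 log units; within the scatter) from compound 2 to compound 4, 20-fold (1.30 log units) apart, beyond the scatter of two such steps. On the core of compound 2 the change gives a 1.6-fold lower number from compound 2 to compound 4 (0.21 log units; within the scatter), so the two compounds cannot be told apart, and the size of this step depends on the core that carries it. The compounds do not show why the two steps differ, and a single pair of steps cannot say how the change would behave on any further core.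

As far as these compounds go, it remains open whether a morpholine ring or a dimethylamino group in the same place would follow the 4-methylpiperazin-1-yl group on both cores. From the compounds shown here alone, whether a piperazine lacking the methyl group would do so is equally open.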